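The compounds below may be only part of what the source reports. "The series", "measured", "known", "first", "only" and "open" are said of these compounds alone.

Measured so far in an ADME assay (liver) for metabolic stability, with Liver microsome (Rattus norvegicus) as the target, read by LC-MS, using microsomes and NADPH, with stated times of 5 min and 60 min, tested at 4 uM; a higher number here means that more of the compound is left, a lower number that less of the compound is left:
- compound 1 `Cc1c(OCCCCOc2ccc(C(=O)O)cc2Cl)ccc(C(=O)CC2CCCC2)c1O`: 21%
- compound 2 `Cc1c(OCCCCOc2ccc(F)c(C(=O)O)c2)ccc(C(=O)CC(C)(C)C)c1O`: 58%

Compound 1 stands lowest of the two numbers. Its nearest neighbour is compound 2, whose number lies higher by a margin beyond the usual scatter of repeated runs. Among the compounds with values here, the two structures differ in more than one place, so no single step can be read from them; the pair shows only that compound 2 leaves more of the compound remaining than compound 1 does. Within the data shown here, no pair of measured compounds differing in exactly one place is available.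

Compound 3 `Cc1ccc(C(=O)O)cc1OCCCCOc1ccc(C(=O)CC2CCCC2)c(O)c1C` is the next member to be measured in this assay. Relative to compound 1 the change is: 5-carboxy-2-methylphenyl in place of 4-carboxy-2-chlorophenyl on an oxygen on a saturated carbon. Among the measured compounds shown here, none of the measured compounds isolates this change, so there is no measured step to lean on, and the expectation rests on compound 1 alone. The step of a number 1 percentage points higher from compound 1 to compound 3 (within the scatter) is expected to be small, within the scatter, with no clear direction. For compound 3 the estimate in this assay is 22%, with a range from 8% to 42%.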

Compound 3, percent of the compound remaining: 9%
Compound 3: the middle estimate sits 13 percentage points above what was measured; the measured number falls inside the stated range.
By their numbers in this assay, from the lowest: compound 3; then compound 1; then compound 2.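

The group on an oxygen on a saturated carbon is not a silent position in this assay: 5-carboxy-2-methylphenyl in place of 4-carboxy-2-chlorophenyl gives a number 12 percentage points lower from compound 1 to compound 3 (beyond the scatter), a modest step, although both groups hold 10 heavy atoms and the same counts of hydrogen-bond donors and acceptors. The swap changes two things at once, with chlorine giving way to methyl and the carboxy group changing its place on the ring, and this one step cannot be divided between them. Nothing measured bears on the reason for the step.

Still open is which of those two changes carries the step, since no compound shown makes either one alone, and compound 2 differs from the others in more than one place, so it cannot settle the question. Also open, from the compounds shown here alone, is how this assay would read with a tetrazole in place of the carboxylic acid on this ring, or with a longer chain between the two oxygens.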